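Estimating Compound 4 from Three Aryl Analogues

A few compounds are considered here, and "the series" means these few. Any claim that something is new, unique, unknown or untested is made for them only; others in the source may bear on it.

Three compounds built on one shared core differ only in the aryl group that sits on an aromatic carbon of a five-membered aromatic ring with 4 nitrogen. Compound 1 `Cc1cc(NC(=O)Cn2nnc(-c3cccc(Cl)c3)n2)n(C2CCCCC2)n1` gives 89% in an assay on HEK293 cells for activation of Kir3.1/Kir3.2 (Homo sapiens), read by thallium flux; on this read-out higher numbers stand for larger maximal responses and lower numbers for smaller maximal responses. Compound 2 `Cc1cc(NC(=O)Cn2nnc(-c3ccc(F)cc3)n2)n(C2CCCCC2)n1` gives 92%, and compound 3 `Cc1cc(NC(=O)Cn2nnc(-c3ccccc3F)n2)n(C2CCCCC2)n1` gives 88%. Compound 3 sits within the usual scatter of both neighbours: a number 1 percentage points lower from compound 1 to compound 3 (within the scatter) and a number 4 percentage points lower from compound 2 to compound 3 (within the scatter), while the remaining comparison, a number 3 percentage points higher from compound 1 to compound 2 (within the scatter), is likewise within the scatter. The unmeasured compound 4 `COc1cccc(-c2nnn(CC(=O)Nc3cc(C)nn3C3CCCCC3)n2)c1` carries a single change relative to compound 3: 3-methoxyphenyl in place of 2-fluorophenyl on an aromatic carbon. All three measured steps exchanged one aryl substituent for another, and none of them moved the maximal response beyond the scatter, so the same quiet outcome is expected for this exchange: a number 2 percentage points higher from compound 3 to compound 4 (within the scatter), with no clear direction. Compound 4 is accordingly estimated at 90%, within a range from 80% to 100%.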

Compound 4, largest response reached (Emax), in percent of the reference or control that the assay uses: 76%
Compound 4: middle estimate off by 14 percentage points, on the high side; the whole stated range lies above it.
By their numbers in this assay, from the lowest: compound 4; then compounds 3, 1 and 2 (each within the scatter of the next).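

At this aromatic carbon of the five-membered aromatic ring with 4 nitrogen, the aryl group proves not to be interchangeable in this assay: the result shows a number 12 percentage points lower from compound 3 to compound 4 (beyond the scatter), a number 16 percentage points lower from compound 2 to compound 4 (beyond the scatter) and a number 13 percentage points lower from compound 1 to compound 4 (beyond the scatter), each beyond the scatter, unlike every step among the three halogen-bearing compounds. The last of these steps exchanges only chloro for methoxy, with 3-chlorophenyl and 3-methoxyphenyl carrying their groups at the same numbered ring position, so the lower response follows the identity of the group and not its ring position alone. No available evidence bears on why the response falls with this change.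

On these data alone, it remains open whether the lower response would also accompany 2-methoxyphenyl or 4-methoxyphenyl. As far as these compounds go, how a hydroxy, ethoxy or dimethylamino group would compare in place of methoxy also remains open.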